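Replacing pyrrolidin-1-yl in compound 2

The source may report more compounds than this note shows. Statements on the series, on what has been measured and on what is new or still open speak of the compounds shown alone.

Measured in a functional assay on MCF7 cells (Homo sapiens) for antiproliferative activity; on this read-out higher numbers stand for weaker inhibition and lower numbers for stronger inhibition:
- compound 1 `CC(C)=CCc1cc(C(=O)Nc2cc3ccc(OCCC4CCCCN4)c(C)c3oc2=O)ccc1O`: 710 nM
- compound 2 `CC(C)=CCc1cc(C(=O)Nc2cc3ccc(OCCCN4CCCC4)c(C)c3oc2=O)ccc1O`: 990 nM

Compound 2, at 990 nM, cannot be told apart from compound 1, at 710 nM, since the two numbers lie within the scatter of each other. Compound 3 `CCN(C)CCCOc1ccc2cc(NC(=O)c3ccc(O)c(CC=C(C)C)c3)c(=O)oc2c1C` keeps the shared core and carries ethyl(methyl)amino in place of pyrrolidin-1-yl on a saturated chain carbon, three bonds along the chain from an oxygen on an aromatic ring. For the measured compounds named here, only one measured step bears on this change. That step, a 1.4-fold higher number from compound 1 to compound 2 (0.14 log units; within the scatter), also altered the amine end of the chain and stayed within the scatter. Going by the values given here, no measured compound has an open-chain amine, so this support is indirect, and no shift beyond the scatter is expected in this assay. The expected step is a 1.1-fold lower number from compound 2 to compound 3 (0.04 log units; within the scatter). Compound 3 is estimated at 900 nM, with an expected range of 450 nM to 1800 nM.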

Compound 3, half-maximal inhibitory concentration: 2190 nM
For compound 3 the middle estimate is 2.4-fold (0.39 log units) below the measured one; the whole stated range lies below it.
By their numbers in this assay, from the lowest: compounds 1 and 2 (each within the scatter of the next); then compound 3.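

In this assay, for the compounds shown here, the amine end of the chain is not indifferent to change: ethyl(methyl)amino in place of pyrrolidin-1-yl gives a 2.2-fold higher number from compound 2 to compound 3 (0.34 log units; beyond the scatter), the first step at this position to pass beyond the scatter, though only modestly. The comparison with the piperidin-2-yl compound points the same way, with a 3.1-fold higher number from compound 1 to compound 3 (0.49 log units; beyond the scatter), so the one open-chain amine here stands apart from the two ring-bearing compounds, which remain within the scatter of each other. Nothing available here accounts for this difference.

As far as these compounds go, whether it extends to open-chain amines in general remains open, and a dimethylamino or diethylamino group on the same propyl chain would bear on that question. Also unsettled is how the result depends on chain length, which a longer chain carrying ethyl(methyl)amino could test.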